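The source may hold more compounds than are shown below. What is called first, only, known or untested is meant among the compounds shown, and "the series" means these compounds.

Compound 1 `CCS(=O)(=O)Nc1ccc(-c2cc(=O)c3c(O)cc(OC)c(OC(C)C)c3o2)cc1` stands lowest of the two numbers measured in a functional assay on CWR22R cells (Homo sapiens) for antiproliferative activity, read by MTT assay, with a stated time of 3 days (on this read-out higher numbers stand for weaker inhibition and lower numbers for stronger inhibition), where compound 1 gives 2900 nM. Within the data shown here, its only measured neighbour, compound 2 `COc1cc(O)c2c(=O)cc(-c3ccc(NS(=O)(=O)C4CC4)cc3)oc2c1OC(C)C`, gives 19700 nM in this assay, and the step of a 6.8-fold higher number from compound 1 to compound 2 (0.83 log units; beyond the scatter) is the single comparison available. Compound 3 `COc1cc(O)c2c(=O)cc(-c3ccc(NC(=O)N4CCN(C)CC4)cc3)oc2c1OC(C)C` differs from compound 1 in the same region of the molecule: (4-methylpiperazin-1-yl)carbonyl in place of ethylsulfonyl on a nitrogen on an aromatic ring. The measured step bears on this change only loosely, since it altered the group on the sulfonyl sulfur while keeping the sulfonyl, whereas the change to compound 3 removes the ethylsulfonyl altogether and brings in (4-methylpiperazin-1-yl)carbonyl. Among the measured compounds shown here, still, the one step recorded at this nitrogen went toward a higher number, so a step of about a 5.2-fold higher number from compound 1 to compound 3 (0.71 log units; beyond the scatter) is expected here as well, toward a higher number in this assay. For compound 3 the number expected in this assay is 15000 nM, with a range from 4000 nM to 60000 nM.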

Compound 3, half-maximal inhibitory concentration: 8800 nM
Compound 3: the middle estimate sits 1.7-fold (0.23 log units) above what was measured; the measured number falls inside the stated range.
By their numbers in this assay, from the lowest: compound 1; then compound 3; then compound 2.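

The nitrogen on the aromatic ring accepts more than a sulfonyl group in this assay: with (4-methylpiperazin-1-yl)carbonyl in place of ethylsulfonyl, the result is a 3.0-fold higher number from compound 1 to compound 3 (0.48 log units; beyond the scatter). The same group in place of cyclopropylsulfonyl gives a 2.2-fold lower number from compound 2 to compound 3 (0.35 log units; beyond the scatter), so the direction of this change depends on which sulfonyl group leaves. The urea-type group thus falls between the two sulfonyl groups, and ethylsulfonyl remains the best of the three at this nitrogen.

On these data alone, whether a methylsulfonyl group, a longer alkyl chain on the sulfonyl sulfur, or a piperazine carbonyl without the methyl group would go below compound 1 remains open. Nothing available here explains why these three groups rank as they do.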